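The source may report more compounds than this note shows. Statements on the series, on what has been measured and on what is new or still open speak of the compounds shown alone.

Compounds measured so far in a functional assay on A549 cells (Homo sapiens) for antiproliferative activity, read by MTT assay, with a stated time of 72 h; on this read-out higher numbers stand for weaker inhibition and lower numbers for stronger inhibition:
compound 1, `Clc1ccc(C2CC(c3ccc(N4CCCCC4)cc3)=NN2c2nc(-c3ccc(Br)cc3)cs2)cc1`, 39700 nM
compound 2, `FC(F)(F)c1ccc(-c2csc(N3N=C(c4ccc(N5CCCCC5)cc4)CC3c3ccc(Cl)cc3)n2)cc1`, 42000 nM
compound 3, `COc1ccc(-c2csc(N3N=C(c4ccc(N5CCCCC5)cc4)CC3c3ccc(Cl)cc3)n2)cc1`, > 100000 nM

Compound 3 does not come with a number in this assay but with a limit: its value of > 100000 nM is the limit of the assay, the point (the limit of > 100000 nM in this assay, at which 1 of the 3 values shown sits). Compound 1 and compound 2 are close to each other, a 1.1-fold higher number from compound 1 to compound 2 (0.02 log units; within the scatter). Compound 3 is set apart from both: an at least 2.5-fold higher number from compound 1 to compound 3 (0.40 log units; beyond the scatter), and an at least 2.3-fold higher number from compound 2 to compound 3 (0.37 log units; beyond the scatter).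

Compound 4, `CS(=O)(=O)c1ccc(-c2csc(N3N=C(c4ccc(N5CCCCC5)cc4)CC3c3ccc(Cl)cc3)n2)cc1`, is made from compound 3 by one change: methylsulfonyl in place of methoxy on an aromatic carbon. Among the compounds with values here, no measured step covers a methylsulfonyl group here; the only steps at hand all end in compound 3 at the limit. Compound 4 is therefore expected to stay near that limit, and the step that the limit leaves unreadable from compound 3 to compound 4 is an estimate, not a measurement. Compound 4 is estimated at 120000 nM, somewhere between 40000 nM and 400000 nM.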

Compound 4, half-maximal inhibitory concentration: > 100000 nM
Compound 4 ended at the assay's limit (the forecaster's own chance of this, stated with the estimate: 70%); the middle value lies beyond the limit too.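

Compound 3 and compound 4 both stop at a limit of this assay, so the step between them cannot be read: the limit of > 100000 nM in this assay, at which 2 of the 4 values shown sit.

Set against bromo, methylsulfonyl gives an at least 2.5-fold higher number from compound 1 to compound 4 (0.40 log units; beyond the scatter), and set against trifluoromethyl it gives an at least 2.3-fold higher number from compound 2 to compound 4 (0.37 log units; beyond the scatter). Methoxy is therefore no longer alone in reaching the limit at this position, and among the four groups shown, only bromo and trifluoromethyl give readable numbers.

As far as these compounds go, how far compound 3 and compound 4 lie beyond the limit remains unknown, so no order can be set between them. Also open, from the compounds shown here alone, is whether an amine or a carboxylic acid at this position would give a readable number, and whether any group here would bring the value well under those of compound 1 and compound 2.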